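This account rests on a few compounds, and the source may have more. Where it says the series, first, only, none or still open, it means among the compounds named here.

Measured in a functional assay on MDA-MB-231 cells (Homo sapiens) for inhibition, read by MTT assay, with a stated time of 72 h; a higher number here means a weaker inhibitor, a lower number a stronger inhibitor:
- compound 1 `CC(C)(C)n1cc2c(n1)C(=O)CC1(CCN(C(=O)c3cc(-c4ccc(Br)cc4)nc4ccccc34)CC1)O2`: > 10000 nM, a limit
- compound 2 `CCOc1cc(C(=O)N2CCC3(CC2)CC(=O)c2nn(C(C)(C)C)cc2O3)c2ccccc2n1`: > 10000 nM, a limit

Among the compounds with values here, neither compound has a numerical value so far. Compound 2 stands only at a limit of this assay, at > 10000 nM, and gives no number from which to count a change. Compound 1 is also known only as a limit, at > 10000 nM. The two compounds share one reading: the limit of > 10000 nM in this assay, at which 2 of the 2 values shown sit.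

Compound 3 `CC(C)Oc1cc(C(=O)N2CCC3(CC2)CC(=O)c2nn(C(C)(C)C)cc2O3)c2ccccc2n1` keeps the core of compound 2 and turns ethoxy into isopropoxy, with methyl in place of hydrogen on a saturated chain carbon bound to an oxygen on an aromatic ring and a saturated chain carbon.

Within the data shown here, only one measured step bears on this change, and it gives no size: a step that the two limits leave unreadable from compound 1 to compound 2. Among the measured compounds shown here, no measured step therefore supports a shift in either direction, so no change beyond the scatter is expected in this assay, and another limit is the likeliest report. The expected step is a step that the limit leaves unreadable from compound 2 to compound 3. Compound 3 is estimated at 15000 nM, with an expected range from 7000 nM to 40000 nM.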

Compound 3, half-maximal inhibitory concentration: > 10000 nM
Compound 3 gave a limit, no number; the forecaster's own chance of this, stated with the estimate: 85%; the middle value does not contradict the limit.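

In this assay compound 3 gives > 10000 nM as a limit and not a number. Within the data shown here, no step from compound 1 or compound 2 to compound 3 can be read, and the three compounds share one reading: the limit of > 10000 nM in this assay, at which 3 of the 3 values shown sit. What the compounds shown leave open is how strongly any of them inhibits, and whether ethoxy, isopropoxy or 4-bromophenyl changes that at all.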